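The compounds below may be only part of what the source reports. "The series", "measured", "known", "first", "only" and "open" are said of these compounds alone.

Measured compounds:
- compound 1 `CCNC(=O)c1noc(-c2cc(C(C)C)c(O)cc2O)c1-c1cc(CO)no1`, 5 nM in a functional assay on A2780 cells (Homo sapiens) for inhibition; on this read-out lower numbers stand for stronger inhibition and higher numbers for weaker inhibition
- compound 2 `CCNC(=O)c1noc(-c2cc(C(C)C)c(O)cc2O)c1-c1cc(CNC)no1`, "not determined" (no result reported) in this assay
- compound 3 `CCNC(=O)c1noc(-c2cc(C(C)C)c(O)cc2O)c1-c1cc(CNC(C)C)no1`, 38 nM in this assay

Going by the values given here, compound 2 stands without a number of its own; its neighbours compound 1 and compound 3 bracket a modest range, and the one measured step, a 7.6-fold higher number from compound 1 to compound 3 (0.88 log units; beyond the scatter), concerns only the group on the saturated chain carbon. Compound 4 `CCCn1ccc(-c2c(C(=O)NCC)noc2-c2cc(C(C)C)c(O)cc2O)n1` differs from compound 2 at the aromatic carbon of the shared core: 1-propyl-1H-pyrazol-3-yl in place of 3-((methylamino)methyl)-1,2-oxazol-5-yl on an aromatic carbon. Among the compounds with values here, no measured step swaps one ring for another, so no step bears on this change directly, and the size of the step in this assay cannot be read off; a modest weakening is plausible but not required. Compound 4 is therefore estimated at 20 nM, expected to fall between 4 nM and 100 nM.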

Compound 4, half-maximal inhibitory concentration: 27 nM
For compound 4 the middle estimate is 1.4-fold (0.13 log units) below the measured one; the measured number falls inside the stated range.
By their numbers in this assay, from the lowest: compound 1; then compounds 4 and 3 (each within the scatter of the next).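

In this assay, the ring at this aromatic carbon can change from a 1,2-oxazole to a pyrazole, and the side chain can change with it, without losing activity altogether: a 1.4-fold lower number from compound 3 to compound 4 (0.15 log units; within the scatter), but a 5.4-fold higher number from compound 1 to compound 4 (0.73 log units; beyond the scatter). Thus 1-propyl-1H-pyrazol-3-yl matches the isopropylamino compound within the scatter but does not match the hydroxymethyl compound. No available evidence accounts for these results.

Steps involving compound 2 cannot be read. Also open, from the compounds shown here alone, is how a butyl chain, or a hydroxymethyl group or an amine on the pyrazole in place of the 1-propyl group, would read here.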